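Aryl swap on the triazole arm of a spiro core

The compounds below may be only part of what the source reports. "The series", "measured", "known", "first", "only" and "open" are said of these compounds alone.

Compound 2 `N#CC1=C(N)Oc2c(N)cc3nc4ccccc4nc3c2C12C(=O)N(Cc1cnnn1-c1c(Cl)cc(Cl)cc1Cl)c1ccccc12`: 37800 nM
Compound 1 `N#CC1=C(N)Oc2c(N)cc3nc4ccccc4nc3c2C12C(=O)N(Cc1cnnn1-c1cc(Cl)ccc1Cl)c1ccccc12`: 33200 nM

In a functional assay on MCF7 cells (Homo sapiens) for antiproliferative activity, read by MTT assay, with a stated time of 48 h (on this read-out higher numbers stand for weaker inhibition and lower numbers for stronger inhibition), compound 2 gives 37800 nM, the higher of the two numbers, and compound 1 gives 33200 nM. Among the measured compounds shown here, the sole step measured, a 1.1-fold higher number from compound 1 to compound 2 (0.06 log units; within the scatter), lies within the scatter. Compound 3 `COc1cc(-n2nncc2CN2C(=O)C3(C(C#N)=C(N)Oc4c(N)cc5nc6ccccc6nc5c43)c3ccccc32)c(OC)cc1Cl` differs from compound 2 by 4-chloro-2,5-dimethoxyphenyl in place of 2,4,6-trichlorophenyl on an aromatic nitrogen. For the measured compounds named here, no measured step speaks to methoxy groups on this ring, and the one aryl change seen moved nothing beyond the scatter, so compound 3 is expected to stay near compound 2, with an estimated step of a 1.1-fold lower number from compound 2 to compound 3 (0.03 log units; within the scatter). Compound 3 is estimated at 35000 nM, between 12000 nM and 110000 nM.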

Compound 3, half-maximal inhibitory concentration: > 50000 nM
Compound 3 ended at the assay's limit; the forecaster's own chance of this, stated with the estimate: 10%; middle value at least 1.4-fold (0.15 log units) away from the limit.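

Compound 3 gives a limit rather than a number in this assay: the limit of > 50000 nM in this assay, at which 1 of the 3 values shown sits. Only floors can be read for this change on the aromatic nitrogen, an at least 1.3-fold higher number from compound 2 to compound 3 (0.12 log units; that floor lies within the scatter) and an at least 1.5-fold higher number from compound 1 to compound 3 (0.17 log units; that floor lies within the scatter), so the 4-chloro-2,5-dimethoxyphenyl group is not shown to differ beyond the scatter from either chlorinated aryl group. Going by these compounds, the true size of both steps stays unknown.

On these data alone, it remains open whether an amine or a carboxylic acid on this aryl ring would give a number clearly lower than those seen so far.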